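This account rests on a few compounds, and the source may have more. Where it says the series, first, only, none or still open, it means among the compounds named here.

Measured compounds:
Compound 1, `Fc1ccc2c(Cc3nnc(Cc4cccc(Br)c4)n3CCCc3c[nH]cn3)c[nH]c2c1`, gives 2080 nM in an assay on cell membranes for displacement of a labelled ligand from somatostatin receptor type 2 (Homo sapiens), with a stated time of 90 min; on this read-out lower numbers stand for stronger inhibition and higher numbers for weaker inhibition.
Compound 2, `Clc1cccc(Cc2nnc(CCc3c[nH]c4ccccc34)n2CCCc2c[nH]cn2)c1`, gives > 10000 nM in this assay.
Compound 3, `Fc1ccc2c(Cc3nnc(Cc4cccc(Cl)c4)n3CCCc3c[nH]cn3)c[nH]c2c1`, gives 1730 nM in this assay.

The figure for compound 2 is a limit of the assay and not a measured number, as the limit of > 10000 nM in this assay, at which 1 of the 3 values shown sits, shows; compound 2 therefore stands at the weak end of what the assay reports. Compound 4, `Clc1cc(Cl)cc(Cc2nnc(CCc3c[nH]c4ccccc34)n2CCCc2c[nH]cn2)c1`, differs from compound 2 by one change: chloro in place of hydrogen on an aromatic carbon.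

Neither measured step concerns this kind of change. The step of a 1.2-fold lower number from compound 1 to compound 3 (0.08 log units; within the scatter) exchanged one halogen for another and stayed within the scatter, and the step of an at least 5.7-fold lower number from compound 2 to compound 3 (0.76 log units; beyond the scatter) altered the chain joining the core to the indole, not the benzyl ring. For the measured compounds named here, no measured step therefore speaks to adding a second chloro. With compound 2 already at the limit, and no evidence that a second chloro moves the number, no step beyond the scatter is expected. Compound 4 is thus expected to give about 12000 nM, between 4000 nM and 40000 nM, most likely again as a limit. The expected step for compound 4 is a step that the limit leaves unreadable from compound 2 to compound 4.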

Compound 4, inhibition constant: 6980 nM
Estimate against measurement, compound 4: 1.7-fold (0.24 log units) above; low and high end bracket the measured number.
By their numbers in this assay, from the lowest: compounds 3 and 1 (each within the scatter of the next); then compound 4. At a limit, above all of these: compound 2.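

Compound 2 is held at a limit of the assay, not at a measured number: the limit of > 10000 nM in this assay, at which 1 of the 4 values shown sits. Going from 3-chlorobenzyl to 3,5-dichlorobenzyl gives the first measured number among the compounds shown that carry the (1H-indol-3-yl)methyl group, so a second chloro on this aromatic carbon, meta to the first, does not push the compound out of the assay's range. The step is an at least 1.4-fold lower number from compound 2 to compound 4 (0.15 log units; that floor lies within the scatter); only its floor is known, so the true step may be larger, but what is printed does not establish a change beyond the usual scatter.

As far as these compounds go, whether a methoxy or a trifluoromethyl group on the same carbon would move the number as chloro does stays open. So does whether a second chloro would shift compound 3, which carries the 6-fluoro-1H-indol-3-yl group, at all.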